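This account rests on a few compounds, and the source may have more. Where it says the series, first, only, none or still open, it means among the compounds named here.

For the measured compounds named here, compound 1 `COc1cc2ncnc(-n3nc(-c4ccccn4)nc3N)c2cc1N` is one of two compounds measured in a physicochemical assay for solubility, in phosphate buffer, with a stated time of 18 h, at pH 7.4 (on this read-out lower numbers stand for lower solubility and higher numbers for higher solubility), where compound 1 gives 3000 nM, the lowest of the two numbers. Its nearest neighbour, compound 2 `COc1cc2ncnc(-n3nc(C4CCCCC4)nc3N)c2cc1OC`, gives 35000 nM in this assay, a gap beyond the scatter. Compound 3 `CCOC(=O)NCCCOc1cc2c(-n3nc(-c4ccccn4)nc3N)ncnc2cc1OC` has not yet been measured. It differs from compound 1 in one place: 3-((ethoxycarbonyl)amino)propoxy in place of amino on an aromatic carbon. Without any step between measured compounds to lean on, the change is expected to shift the read-out little, if at all beyond the scatter, with the step of no change at the digits printed from compound 1 to compound 3 (within the scatter) estimated. Compound 3 is accordingly expected to give about 3000 nM, within 600 nM to 15000 nM.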

Compound 3, solubility: 16000 nM
Compound 3: the middle estimate sits 5.3-fold (0.73 log units) below what was measured, outside the stated range (above it).
By their numbers in this assay, from the lowest: compound 1; then compound 3; then compound 2.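

In this assay, 3-((ethoxycarbonyl)amino)propoxy in place of amino on this aromatic carbon, ortho to a methoxy group, gives a 5.3-fold higher number from compound 1 to compound 3 (0.73 log units; beyond the scatter), so the position carries a chain of 10 heavy atoms without the number falling. No evidence at hand bears on why the number rises.

From the compounds shown here alone, whether the rise belongs to the whole chain or to its ethoxycarbonyl end stays open: a plain propoxy, a 3-aminopropoxy or a chain ending in a carboxylic acid at this position would separate the two.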